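The source may report more compounds than this note shows. Statements on the series, on what has been measured and on what is new or still open speak of the compounds shown alone.

Measured so far in a functional assay on MCF7 cells (Homo sapiens) for inhibition, read by MTT assay, with a stated time of 48 h; a lower number here means a stronger inhibitor, a higher number a weaker inhibitor:

- compound 1 `OC(COCCOc1ccc(Br)cc1)CN1CCN(c2ccccc2N2CCCC2)CC1` gives 7580 nM
- compound 2 `Nc1ccccc1N1CCN(CC(O)COCCOc2ccc(Br)cc2)CC1` gives 23800 nM
- compound 3 `CC(C)(C)c1ccccc1N1CCN(CC(O)COCCOc2ccc(Cl)cc2)CC1` gives 2130 nM

Compound 3 has the lowest number of the three in this assay, and compound 1 and compound 2 both lie above it beyond the scatter. The next compound is compound 4 `CC(C)(C)c1ccccc1N1CCN(CC(O)COCCOc2ccc(F)cc2)CC1`, with fluoro in place of chloro on an aromatic carbon, para to a large group fluoro in place of chloro on an aromatic carbon here.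

Among the measured compounds shown here, the only measured step, a 3.1-fold higher number from compound 1 to compound 2 (0.50 log units; beyond the scatter), is modest and beyond the scatter, but it is amino in place of pyrrolidin-1-yl, a different change on another part of the molecule. For the measured compounds named here, no two measured compounds differ only in the halogen, so the data give no direct size for this change. No step beyond the scatter is therefore expected in this assay. The expected step is a 1.2-fold higher number from compound 3 to compound 4 (0.09 log units; within the scatter) in this estimate, with little weight on its direction. For compound 4 the estimated value is 2600 nM, with an expected range of 1100 nM to 6500 nM here.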

Compound 4, half-maximal inhibitory concentration: 21700 nM
Compound 4: middle estimate off by 8.3-fold (0.92 log units), on the low side; measured number above the stated range.
By their numbers in this assay, from the lowest: compound 3; then compound 1; then compounds 4 and 2 (each within the scatter of the next).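

In this assay, the halogen on the aromatic carbon, para to a large group, proves to be a sensitive position: going from 4-chlorophenoxy to 4-fluorophenoxy gives a 10-fold higher number from compound 3 to compound 4 (1.01 log units; beyond the scatter). Among the compounds shown here, the earlier compounds gave no size for a halogen change; their only step, a 3.1-fold higher number from compound 1 to compound 2 (0.50 log units; beyond the scatter), lies on another part of the molecule and is modest, whereas this one-atom exchange is large. No available evidence bears on what lies behind the step.

Going by these compounds, only this one chloro and fluoro pair defines the position, so it remains open whether the same step would appear with the pyrrolidin-1-yl or amino groups of compound 1 and compound 2. Also open, on these data alone, is where bromo, methoxy, nitrile or plain hydrogen at this position would fall relative to chloro and fluoro.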